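Swapping an Ethynyl for a 3-Cyanophenyl Group

The source may report more compounds than this note shows. Statements on the series, on what has been measured and on what is new or still open speak of the compounds shown alone.

Of the compounds shown here, three sharing one boron-containing core have been tested in a functional assay on HCT-116 cells (Homo sapiens) for antiproliferative activity, read by MTT assay, with a stated time of 72 h; on this read-out higher numbers stand for weaker inhibition and lower numbers for stronger inhibition. Compound 1 `O=C(CCc1cccc2c1B(O)OC2)Nc1ccc(Br)cc1` gives 46000 nM. Compound 2 `O=C(CCc1cccc2c1B(O)OC2)Nc1ccc([N+](=O)[O-])cc1` reaches only (the limit of > 100000 nM in this assay, at which 1 of the 3 values shown sits), recorded as > 100000 nM. For the measured compounds named here, the one measured change within this set is an at least 2.1-fold higher number from compound 1 to compound 2 (0.33 log units; beyond the scatter). Compound 3 `C#Cc1cccc(NC(=O)CCc2cccc3c2B(O)OC3)c1` gives 3600 nM, the lowest of the two numbers that are not limits, with compound 1 standing well above it, beyond the scatter.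

Compound 4 `N#Cc1cccc(-c2cccc(NC(=O)CCc3cccc4c3B(O)OC4)c2)c1` has not yet been measured. It differs from compound 3 in one place (3-cyanophenyl in place of ethynyl on an aromatic carbon). Going by the values given here, the single measured step concerns a bromo-to-nitro swap on a different part of the molecule and offers no direct guide to this much larger replacement, so the step expected here in this assay is a 1.4-fold higher number from compound 3 to compound 4 (0.14 log units; within the scatter), a change that may well stay within the scatter, with a wide range on either side. Compound 4 is therefore estimated at 5000 nM, spanning from 1200 nM to 25000 nM.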

Compound 4, half-maximal inhibitory concentration: 140 nM
Estimate against measurement, compound 4: 36-fold (1.55 log units) above; the measured number lies below the stated range.
By their numbers in this assay, from the lowest: compound 4; then compound 3; then compound 1. At a limit, above all of these: compound 2.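

In this assay, 3-cyanophenyl in place of ethynyl gives a 26-fold lower number from compound 3 to compound 4 (1.41 log units; beyond the scatter), a large step that lies beyond the scatter. This shows that the position, meta to a large group, accepts a whole extra aromatic ring with no loss of activity, and that in this pair the bigger group goes with much stronger inhibition. Nothing measured here explains this gain.

From the compounds shown here alone, it remains open whether the gain comes from the added aromatic ring itself or from its nitrile, and whether a plain phenyl, or a phenyl carrying an amine or a carboxylic acid instead of the nitrile, would perform as well. Also open, going by these compounds, is whether the 3-cyanophenyl group would have a similar effect at other positions on this ring.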